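A longer chain on an inactive compound

The source may report more compounds than this note shows. Statements on the series, on what has been measured and on what is new or still open speak of the compounds shown alone.

Results so far in a functional assay on DU-145 cells (Homo sapiens) for cytotoxicity, read by MTT assay, with a stated time of 24 h (on this read-out lower numbers stand for stronger inhibition and higher numbers for weaker inhibition), follow
- compound 1 (`CCCCCCCC/C=C\CCCCCCCC(=O)Nc1nnc(S[C@@H]2O[C@H](COC(C)=O)[C@H](OC(C)=O)[C@H](OC(C)=O)[C@H]2OC(C)=O)s1`): 42000 nM
- compound 2 (`CCCCCCCC(=O)Nc1nnc(S[C@@H]2O[C@H](CO)[C@H](O)[C@H](O)[C@H]2O)s1`): "not active" (no number reported)
- compound 3 (`CCCCCCCC/C=C\CCCCCCCCCCCC(=O)Nc1nnc(S[C@@H]2O[C@H](COC(C)=O)[C@H](OC(C)=O)[C@H](OC(C)=O)[C@H]2OC(C)=O)s1`): 28400 nM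

Compound 2 has no single number in this assay and stands only as ("not active" (no number reported)), so it offers no numerical starting point. Compound 1 and compound 3 do give numbers, and their two values lie within the usual scatter of each other. Among the compounds with values here, both differ from compound 2 in more than one place, however, so neither gives a clean step to build on, and no step between measured compounds exists.

Compound 4 (`CCCCCCCCCCCCCC(=O)Nc1nnc(S[C@@H]2O[C@H](CO)[C@H](O)[C@H](O)[C@H]2O)s1`) has not yet been measured. Its structural change is hexyl in place of hydrogen on a saturated chain carbon, seven bonds along the chain from a carbonyl carbon, that is, hexyl in place of hydrogen on a saturated chain carbon. Nothing else separates it from compound 2.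

With compound 2 reported as ("not active" (no number reported)), only a modest step is expected in this assay, directed if at all towards stronger inhibition, and a second report without a number remains quite possible. If a number is reported, compound 4 is estimated at (60000 nM), with an expected range of (25000 nM to 150000 nM).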

Compound 4, half-maximal inhibitory concentration: "not active" (no number reported)
The entry for compound 4 holds no number, and the estimate cannot be compared.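

In this assay, within the data shown here, compound 2 and compound 4 are both reported without a number, so no step between them can be read. The compounds shown leave open whether hexyl in place of hydrogen changes this assay at all on a compound that gives a measurable value. No evidence at hand bears on this result.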